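This account rests on a few compounds, and the source may have more. Where it says the series, first, only, none or still open, it means among the compounds named here.

Three compounds have so far been measured in a functional assay on CHO cells for inhibition of transient receptor potential cation channel subfamily V member 1 (Homo sapiens); a lower number here means a stronger inhibitor, a higher number a weaker inhibitor:

compound 1 `CC(C)(C)c1ccc(CCC(=O)Nc2ccc3c(c2)OCCO3)cc1` – 150 nM
compound 2 `CC(C)(C)c1ccc(C2CC2C(=O)Nc2ccc3c(c2)OCCO3)cc1` – 1800 nM
compound 3 `CC(C)(C)c1ccc(/C(=C/C(=O)Nc2ccc3c(c2)OCCO3)Cc2ccccc2)cc1` – 14 nM

Compound 3 has the lowest of the three numbers, that is, it is the strongest inhibitor of the set. Its nearest neighbour is compound 1, whose number is higher by a gap beyond the usual scatter of this assay; compound 2 lies further away still, also beyond the scatter. Going by the values given here, none of these pairs differs in a single place, so no measured step connects them.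

Compound 4 `CN(C)CCC/C(=C\C(=O)Nc1ccc2c(c1)OCCO2)c1ccc(C(C)(C)C)cc1` has not yet been measured. It differs from compound 3 in one place: 2-(dimethylamino)ethyl in place of phenyl on a saturated chain carbon bound to a double-bonded chain carbon. Among the compounds with values here, no measured pair shows what a change of this kind does, so the direction can only be guessed from the structures. A modest loss of potency is expected, a step of a 4.3-fold higher number from compound 3 to compound 4 (0.63 log units; beyond the scatter) in this assay. Compound 4 is therefore estimated at 60 nM, with a likely range from 12 nM to 400 nM.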

Compound 4, half-maximal inhibitory concentration: 3900 nM
Compound 4: middle estimate off by 65-fold (1.81 log units), on the low side; measured number above the stated range.
By their numbers in this assay, from the lowest: compound 3; then compound 1; then compound 2; then compound 4.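

In this assay, putting 2-(dimethylamino)ethyl in place of phenyl gives a 280-fold higher number from compound 3 to compound 4 (2.44 log units; beyond the scatter), a large step towards weaker inhibition. Going by these compounds alone, this is the first single-place change in the set, and it shows that the group on this saturated chain carbon, bound to a double-bonded chain carbon, can strongly shift the number: the change removes an aromatic ring of carbon only and brings in a ringless group with one nitrogen and one hydrogen-bond acceptor. No measurement shown here explains why the number rises so far.

The compounds shown leave open whether the step follows from losing the ring or from gaining the nitrogen, as both changes arrive together. A plain butyl chain, which has no nitrogen, and a dimethylaminophenyl group, which keeps the ring and carries the amine, would each pull these two changes apart.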